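Hydroxyethoxymethyl chain on the shared core: expected inhibition

The source may hold more compounds than are shown below. What is called first, only, known or untested is meant among the compounds shown, and "the series" means these compounds.

Three compounds share one core and differ only in the chain on a saturated chain carbon bound to an aromatic nitrogen. In a functional assay on ileum for inhibition of histamine H1 receptor (Cavia porcellus) (on this read-out lower numbers stand for stronger inhibition and higher numbers for weaker inhibition), compound 1 `CC(C)CCn1c(N2CCN(C)CC2)nc2ccccc21` gives 1400 nM, compound 2 `CCCSCn1c(N2CCN(C)CC2)nc2ccccc21` gives 68 nM and compound 3 `CCCC(C)Cn1c(N2CCN(C)CC2)nc2ccccc21` gives 500 nM. Compound 3 stands second highest of the three numbers: its nearest neighbour is compound 1, through a 2.8-fold lower number from compound 1 to compound 3 (0.45 log units; beyond the scatter), and its furthest is compound 2, through a 7.4-fold higher number from compound 2 to compound 3 (0.87 log units; beyond the scatter).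

Compound 4 `CN1CCN(c2nc3ccccc3n2CCOCCO)CC1` has not been measured. It differs from compound 3 by (2-hydroxyethoxy)methyl in place of 1-methylbutyl on a saturated chain carbon bound to an aromatic nitrogen. Of the measured steps, a 7.4-fold higher number from compound 2 to compound 3 (0.87 log units; beyond the scatter) bears most on it, since it also set a chain carrying a heteroatom against an all-carbon chain; a 2.8-fold lower number from compound 1 to compound 3 (0.45 log units; beyond the scatter) compares two all-carbon chains and guides less, and a 21-fold lower number from compound 1 to compound 2 (1.31 log units; beyond the scatter) is the same exchange seen from compound 1. No chain carrying oxygen or a hydrogen-bond donor has been measured, so the direction rests on one comparison. The step expected here is a 1.7-fold lower number from compound 3 to compound 4 (0.22 log units; within the scatter), a modest lowering with wide uncertainty. Compound 4 in this assay is estimated at 300 nM, expected between 80 nM and 1500 nM.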

Compound 4, half-maximal inhibitory concentration: 42 nM
For compound 4 the middle estimate is 7.1-fold (0.85 log units) above the measured one; measured number below the stated range.
By their numbers in this assay, from the lowest: compounds 4 and 2 (each within the scatter of the next); then compound 3; then compound 1.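

In this assay, the (2-hydroxyethoxy)methyl chain, the only chain shown with oxygen and a hydrogen-bond donor, is well accepted at this position on a saturated chain carbon bound to an aromatic nitrogen, and clearly outperforms both all-carbon chains (a 12-fold lower number from compound 3 to compound 4 (1.08 log units; beyond the scatter); a 33-fold lower number from compound 1 to compound 4 (1.52 log units; beyond the scatter)). Against the propylsulfanyl chain the difference stays small (a 1.6-fold lower number from compound 2 to compound 4 (0.21 log units; within the scatter)), so the two chains carrying heteroatoms cannot be told apart, and both stand clear of the all-carbon chains of compound 1 and compound 3. Nothing available accounts for this gain.

The chain brings an ether oxygen and a terminal hydroxyl together, and the compounds shown do not separate the two. Still open, on these data alone, is how a methoxyethyl chain, a longer chain ending in hydroxyl, or a chain ending in an amine or a carboxylic acid would read out in this assay.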